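The source may hold more compounds than are shown below. What is called first, only, known or untested is meant among the compounds shown, and "the series" means these compounds.

Measured so far:
compound 1 `COc1ccc2c(=O)c(/C=C/C(=O)Nc3ccccc3)coc2c1`: > 100000 nM
compound 2 `COc1ccc2c(=O)c(/C=C/C(=O)Nc3ccccc3Cl)coc2c1`: 22400 nM
compound 3 `COc1ccc2c(=O)c(/C=C/C(=O)NCc3cccc(F)c3)coc2c1`: 17600 nM

In a functional assay on HeLa cells (Homo sapiens) for inhibition, read by MTT assay, with a stated time of 48 h (on this read-out lower numbers stand for stronger inhibition and higher numbers for weaker inhibition), compound 1 gives only a limit, > 100000 nM, not a number. Compound 1 thus stands at the limit of > 100000 nM in this assay, at which 1 of the 3 values shown sits. Compound 2 gives 22400 nM and compound 3 gives 17600 nM. All measured steps concern the group on the amide nitrogen: an at least 4.4-fold lower number from compound 1 to compound 2 (0.64 log units; beyond the scatter), an at least 5.6-fold lower number from compound 1 to compound 3 (0.75 log units; beyond the scatter) and a 1.3-fold lower number from compound 2 to compound 3 (0.10 log units; within the scatter).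

Compound 4 `O=C(/C=C/c1coc2cc(O)ccc2c1=O)Nc1ccccc1` differs from compound 1 at another place: hydrogen in place of methyl on an oxygen on an aromatic ring. Within the data shown here, no measured step touches this oxygen, so none of them bears on the change, and the starting point itself is a limit. The expected step is a number no higher from compound 1 to compound 4 (the limit leaves the size open). Compound 4 is estimated at 100000 nM, with a range from 30000 nM to 300000 nM.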

Compound 4, half-maximal inhibitory concentration: 9700 nM
Estimate against measurement, compound 4: 10-fold (1.01 log units) above; measured number below the stated range.
By their numbers in this assay, from the lowest: compounds 4, 3 and 2 (each within the scatter of the next, the first and the last beyond it). At a limit, above all of these: compound 1.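

Hydroxy in place of methoxy on the aromatic ring gives an at least 10-fold lower number from compound 1 to compound 4 (1.01 log units; beyond the scatter) in this assay, the only measured step away from the amide nitrogen. With the phenyl amide kept, this single change on the oxygen brings compound 4 to 9700 nM, so this oxygen also governs the read-out. Compound 1 gives a limit and not a number: the limit of > 100000 nM in this assay, at which 1 of the 4 values shown sits.

Still open, as far as these compounds go, is how ethyl or acetyl on this oxygen, or an amine in its place, would read. Also open, from the compounds shown here alone, is whether hydroxy adds to the 2-chlorophenyl and 3-fluorobenzyl amides of compound 2 and compound 3.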